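The compounds below may be only part of what the source reports. "The series", "measured", "known", "first", "only" and "open" are said of these compounds alone.

Measured compounds:
compound 1, `CCC(c1ccccc1)c1nc(-c2ccc(Cl)cc2)c(CC(=O)O)s1`, 190 nM;
compound 2, `O=C(O)Cc1sc(C(c2ccc(F)cc2)c2ccc(F)cc2)nc1-c1ccoc1`, 14 nM;
compound 3, `O=C(O)Cc1sc(C(c2ccccc2)c2ccc(F)c(F)c2)nc1-c1ccc(F)cc1`, 10 nM.

In an in vitro assay on HEK385-7 cells for displacement of a labelled ligand from prostaglandin D2 receptor 2 (Homo sapiens) (on this read-out lower numbers stand for stronger inhibition and higher numbers for weaker inhibition), compound 1 stands highest of the three numbers, beyond the scatter from both compound 2 and compound 3. Compound 4, `O=C(O)Cc1sc(C(Cc2ccccc2)c2ccccc2)nc1-c1ccc(Cl)cc1`, has not yet been measured in this assay. It differs from compound 1 by phenyl in place of methyl on a saturated chain carbon, two bonds along the chain from two aromatic carbons. Going by the values given here, no measured pair shows this change, so its size is open. The lower numbers of compound 2, 14 nM, and compound 3, 10 nM, show that the shared core can reach well below compound 1. Compound 4 is therefore expected to give a lower number than compound 1, a step of about a 3.2-fold lower number from compound 1 to compound 4 (0.50 log units; beyond the scatter), beyond the scatter. Compound 4 is estimated at 60 nM, with a range of 20 nM to 200 nM.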

Compound 4, half-maximal inhibitory concentration: 56 nM
Compound 4: the middle estimate sits 1.1-fold (0.03 log units) above what was measured; the range from low to high includes it.
By their numbers in this assay, from the lowest: compounds 3 and 2 (each within the scatter of the next); then compound 4; then compound 1.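

Phenyl in place of methyl on a saturated chain carbon, two bonds along the chain from two aromatic carbons, gives a 3.4-fold lower number from compound 1 to compound 4 (0.53 log units; beyond the scatter) in this assay and so shows that this position takes the larger group with a modest gain. Going by these compounds alone, this is the first pair to show this change at this position. Nothing measured here accounts for the step.

As far as these compounds go, whether a longer chain or an amine at this position would lower the number further remains open. So does whether the same change would give a step of similar size alongside the other groups carried by compound 2 and compound 3.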